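A few compounds are considered here, and "the series" means these few. Any claim that something is new, unique, unknown or untested is made for them only; others in the source may bear on it.

Measured so far in a functional assay on HEK293 cells for agonist activity at D(4) dopamine receptor (Homo sapiens), read by FLIPR; on this read-out lower numbers stand for smaller maximal responses and higher numbers for larger maximal responses:

- compound 1 `Cc1cccc(NC(=O)CN2CCC(c3nccs3)CC2)c1`: 62%
- compound 2 `Cc1cc(C)cc(NC(=O)CN2CCC(c3cccc[n+]3[O-])CC2)c1`: 76%

Compound 2 stands highest of the two numbers in this assay; its nearest neighbour is compound 1, whose maximal response is lower by a gap beyond the usual scatter. The two differ in more than one place, so nothing is read from that gap as a single step.

Compound 3 `Cc1cc(NC(=O)CN2CCC(c3cccc[n+]3[O-])CC2)ccc1F` has not been measured. It differs from compound 2 in one place: 4-fluoro-3-methylphenyl in place of 3,5-dimethylphenyl on an amide-type nitrogen. Among the compounds with values here, the ring that leaves and the ring that enters match in heavy-atom count, donor count, acceptor count and charge, and no measured pair isolates a change of this kind, so no direction can be taken from the data.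

The step from compound 2 to compound 3 is expected to be small, a number 6 percentage points lower from compound 2 to compound 3 (within the scatter), not clearly beyond the scatter in either direction. For compound 3 the maximal response in this assay is estimated at 70%, with a likely range from 50% to 90%.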

Compound 3, largest response reached (reported as efficacy), in percent of the reference or control that the assay uses: 75%
Beside the measured number, compound 3's estimate is 5 percentage points below it; the range from low to high includes it.
By their numbers in this assay, from the lowest: compound 1; then compounds 3 and 2 (each within the scatter of the next).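

In this assay, within the data shown here, putting 4-fluoro-3-methylphenyl in place of 3,5-dimethylphenyl on the amide-type nitrogen gives a number 1 percentage points lower from compound 2 to compound 3 (within the scatter) as the first single-place step. On this read-out, the maximal response does not separate these two rings, which match in heavy-atom count and carry no hydrogen-bond donors or acceptors. No measurement shown explains this result.

The step combines the loss of a methyl group and the gain of a fluorine atom, so the share of each cannot be read separately. Also open, on these data alone, is whether the response holds with a different group on the amide-type nitrogen, such as a pyridyl ring or a benzyl group, or with a methoxy group in place of the fluorine.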